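Dimethoxypyrimidine in place of dimethylpyrimidine on the sulfonamide nitrogen

A few compounds are considered here, and "the series" means these few. Any claim that something is new, unique, unknown or untested is made for them only; others in the source may bear on it.

Compound 2 `Cc1cc(C)nc(NS(=O)(=O)c2ccc(N/C(S)=N\c3ccnc4cc(C(F)(F)F)ccc34)cc2)n1` and compound 1 `Cc1ccnc(NS(=O)(=O)c2ccc(N/C(S)=N\c3ccnc4cc(C(F)(F)F)ccc34)cc2)n1` share one core and differ only in a methyl in place of hydrogen on an aromatic carbon. In a functional assay on LoVo cells (Homo sapiens) for antiproliferative activity, read by sulforhodamine B assay, with a stated time of 48 h (on this read-out higher numbers stand for weaker inhibition and lower numbers for stronger inhibition), compound 1 gives 31000 nM, and compound 2 gives 40200 nM. The step of a 1.3-fold higher number from compound 1 to compound 2 (0.11 log units; within the scatter) is within the scatter, so compound 2 has the higher of the two numbers but cannot be separated from compound 1. Compound 3 `COc1cc(NS(=O)(=O)c2ccc(N/C(S)=N\c3ccnc4cc(C(F)(F)F)ccc34)cc2)nc(OC)n1` carries the change (2,6-dimethoxypyrimidin-4-yl in place of 4,6-dimethylpyrimidin-2-yl on a sulfonamide nitrogen). Among the compounds with values here, no measured step exchanges one pyrimidine for another; the only step available, a 1.3-fold higher number from compound 1 to compound 2 (0.11 log units; within the scatter), shows that a small change on the pyrimidine ring left this assay essentially unchanged. On that basis only a small step is expected, a 1.1-fold lower number from compound 2 to compound 3 (0.06 log units; within the scatter), with no clear direction and wide uncertainty. Compound 3 is therefore estimated at 35000 nM in this assay, within a range from 10000 nM to 100000 nM.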

Compound 3, half-maximal inhibitory concentration: 76700 nM
Compound 3: the middle estimate sits 2.2-fold (0.34 log units) below what was measured, within the range that was stated.
By their numbers in this assay, from the lowest: compounds 1, 2 and 3 (each within the scatter of the next, the first and the last beyond it).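

In this assay, putting 2,6-dimethoxypyrimidin-4-yl in place of 4,6-dimethylpyrimidin-2-yl on the sulfonamide nitrogen gives a 1.9-fold higher number from compound 2 to compound 3 (0.28 log units; within the scatter) and so leaves that pair inseparable, even though the entering group carries two more hydrogen-bond acceptors. Set against the 4-methylpyrimidin-2-yl group, the same entering group gives a 2.5-fold higher number from compound 1 to compound 3 (0.39 log units; beyond the scatter) and thereby provides the first step at this position to pass beyond the scatter, though only modestly. Nothing available explains this shift, and no cause can be assigned to it.

All three compounds carry a pyrimidine on this nitrogen and differ only in methyl or methoxy groups on it. As far as these compounds go, it remains open how the numbers would respond to an amine or a carboxylic acid on that ring, or to a pyridine in place of the pyrimidine.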